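Aryl amide variation in a weak antiproliferative series

A few compounds are considered here, and "the series" means these few. Any claim that something is new, unique, unknown or untested is made for them only; others in the source may bear on it.

Measured compounds and values in a functional assay on HeLa cells (Homo sapiens) for antiproliferative activity, read by MTT assay, with a stated time of 72 h; a higher number here means a weaker inhibitor, a lower number a stronger inhibitor:
compound 1, `O=C(Nc1ccc(Cl)c(-c2nnc3c(Cl)cccn23)c1)c1ccccn1`: 75500 nM
compound 3, `O=C(Nc1ccc(Cl)c(-c2nnc3c(Cl)cccn23)c1)c1cccnc1Cl`: 87500 nM
compound 2, `O=C(Nc1ccc(Cl)c(-c2nnc3c(Cl)cccn23)c1)c1ccon1`: a limit only, > 100000 nM, namely the limit of > 100000 nM in this assay, at which 1 of the 3 values shown sits.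

Of the two numbers shown, compound 3 gives the larger one, yet only by a 1.2-fold higher number from compound 1 to compound 3 (0.06 log units; within the scatter). The unmeasured compound 4, `CS(=O)(=O)c1cccc(C(=O)Nc2ccc(Cl)c(-c3nnc4c(Cl)cccn34)c2)c1`, differs from compound 3 by 3-(methylsulfonyl)phenyl in place of 2-chloropyridin-3-yl on a carbonyl carbon. Every earlier change at this carbonyl carbon moved this assay little: an at least 1.3-fold higher number from compound 1 to compound 2 (0.12 log units; that floor lies within the scatter), a 1.2-fold higher number from compound 1 to compound 3 (0.06 log units; within the scatter) and an at least 1.1-fold lower number from compound 2 to compound 3 (0.05 log units; that floor lies within the scatter). No step beyond the scatter is therefore expected from compound 3 to compound 4, and a limit rather than a number remains quite possible. Compound 4 is expected to give 90000 nM, with a range from 40000 nM to 200000 nM, meaning a 1.0-fold higher number from compound 3 to compound 4 (0.01 log units; within the scatter).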

Compound 4, half-maximal inhibitory concentration: 86400 nM
The estimate for compound 4 lay 1.0-fold (0.02 log units) above the measured number, within the range that was stated.
By their numbers in this assay, from the lowest: compounds 1, 4 and 3 (each within the scatter of the next). At a limit, above all of these: compound 2.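

With 3-(methylsulfonyl)phenyl on the carbonyl carbon, the aromatic ring there is of carbon only, and this assay still stays flat: a 1.0-fold lower number from compound 3 to compound 4 (0.01 log units; within the scatter) and a 1.1-fold higher number from compound 1 to compound 4 (0.06 log units; within the scatter). A ring hetero atom is thus not required to hold this weak level among the compounds shown. Against compound 2 only a floor can be read, an at least 1.1-fold lower number from compound 2 to compound 4 (0.06 log units; that floor lies within the scatter), since compound 2 stands at a limit: the limit of > 100000 nM in this assay, at which 1 of the 4 values shown sits.

On these data alone, whether a saturated piperidine ring on the carbonyl carbon, or a carboxylic acid or an amine on the phenyl ring, would bring the number down stays open. So does whether any change on the shared core would do so.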